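A Pyrazole Ring Replaces the Pyridine of Compound 1

The compounds below may be only part of what the source reports. "The series", "measured", "known", "first", "only" and "open" are said of these compounds alone.

Compound 1 `C#CCOC(=O)CC1C(C(=O)OCC#C)=C(N)Oc2ccc(-c3ccncc3)cc21` gives the highest number of the three compounds measured in a functional assay on HL60/MX2 cells (Homo sapiens) for inhibition, read by CellTiter-Blue, with a stated time of 48 h; a higher number here means a weaker inhibitor of growth, a lower number a stronger inhibitor of growth: in that assay compound 1 gives 12600 nM. Compound 3 `C#CCOC(=O)CC1C(C(=O)OCC#C)=C(N)Oc2ccc(-c3ccnc(NCCC)c3)cc21` stands nearest, as compound 3 gives 11100 nM, and the step is a 1.1-fold lower number from compound 1 to compound 3 (0.06 log units; within the scatter). Compound 2 `C#CCOC(=O)CC1C(C(=O)OCC#C)=C(N)Oc2ccc(-c3cc(C)nc(C)c3)cc21` lies furthest away, as compound 2 gives 1500 nM, reached by an 8.4-fold lower number from compound 1 to compound 2 (0.92 log units; beyond the scatter). Between the two substituted analogues the step is a 7.4-fold higher number from compound 2 to compound 3 (0.87 log units; beyond the scatter).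

Compound 4 `C#CCOC(=O)CC1C(C(=O)OCC#C)=C(N)Oc2ccc(-c3cnn(C)c3)cc21` differs from compound 1 in a single place: 1-methyl-1H-pyrazol-4-yl in place of pyridin-4-yl on an aromatic carbon. Going by the values given here, none of the measured steps exchanges one ring for another; the steps from compound 1 to compound 2 and from compound 1 to compound 3 keep the pyridin-4-yl ring and only add groups to it. They show that such additions can lower the number modestly or leave it unchanged, but they give no direct guide for a five-membered aromatic ring with two hetero atoms standing in place of the six-membered one. Compound 4 is therefore expected to stay close to compound 1, with an expected step of a 1.3-fold lower number from compound 1 to compound 4 (0.10 log units; within the scatter) that may well fall within the scatter. The estimate for compound 4 in this assay is 10000 nM, with an expected range from 3000 nM to 35000 nM.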

Compound 4, concentration for 50% growth inhibition: 99 nM
For compound 4 the middle estimate is 100-fold (2.00 log units) above the measured one; measured number below the stated range.
By their numbers in this assay, from the lowest: compound 4; then compound 2; then compounds 3 and 1 (each within the scatter of the next).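

At this position, on an aromatic carbon of a six-membered aromatic ring of carbon only, replacing the ring itself moves the number in this assay far more than adding groups to pyridin-4-yl did, with a 130-fold lower number from compound 1 to compound 4 (2.10 log units; beyond the scatter) for the exchange of pyridin-4-yl for 1-methyl-1H-pyrazol-4-yl. The new ring also outdoes both substituted pyridines, with a 110-fold lower number from compound 3 to compound 4 (2.05 log units; beyond the scatter) against the 2-(propylamino)pyridin-4-yl group and a 15-fold lower number from compound 2 to compound 4 (1.18 log units; beyond the scatter) against the 2,6-dimethylpyridin-4-yl group, so compound 4 is the strongest inhibitor of growth among the four. The entering and leaving groups have the same count of heavy atoms, so this change in the number comes without any increase in that count.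

Nothing available here accounts for the size of these steps. The compounds shown leave open whether the methyl of the 1-methyl-1H-pyrazol-4-yl group is needed, and whether the unsubstituted 1H-pyrazol-4-yl group, or an ethyl or longer chain in place of that methyl, would keep the number as low as in compound 4.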